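Dropping One Chloro Group from Compound 1

The source may hold more compounds than are shown below. What is called first, only, known or untested is meant among the compounds shown, and "the series" means these compounds.

Compound 1 `ClCc1ccccc1Cn1cnc2nc(Cl)nc(Cl)c21` carries chloro groups on its fused core and a side arm that bears a chloromethyl group. In a functional assay on BT-549 cells (Homo sapiens) for cytotoxicity, read by sulforhodamine B assay, with a stated time of 48 h (a lower number here means a stronger inhibitor of growth, a higher number a weaker inhibitor of growth), compound 1 gives 3090 nM, the lower of the two numbers recorded so far. Its close relative, compound 2 `ClCc1ccc(Cn2cnc3c(Cl)nc(Cl)nc32)cc1`, differs in how the side arm is arranged, and in this assay compound 2 gives 29500 nM, a weaker result by a margin beyond the usual scatter. Compound 3 `ClCc1ccccc1Cn1cnc2ncnc(Cl)c21` has not been measured; it differs from compound 1 by a single change: hydrogen in place of chloro on an aromatic carbon. Among the measured compounds shown here, no measured pair shows the effect of this particular change, so the outlook rests on compound 1 alone. Removing the chloro is expected to cost some activity, a step of modest size toward a higher number in this assay, a 2.3-fold higher number from compound 1 to compound 3 (0.36 log units; beyond the scatter). Compound 3 is therefore expected to give about 7000 nM in this assay, with a likely range from 2000 nM to 25000 nM.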

Compound 3, concentration for total growth inhibition: 6020 nM
Compound 3: the middle estimate sits 1.2-fold (0.07 log units) above what was measured; low and high end bracket the measured number.
By their numbers in this assay, from the lowest: compounds 1 and 3 (each within the scatter of the next); then compound 2.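

In this assay, the step is a 1.9-fold higher number from compound 1 to compound 3 (0.29 log units; within the scatter), made by replacing the chloro on the aromatic carbon between two ring nitrogen atoms with hydrogen. Among the compounds shown here, this is the first direct look at this position, and it shows that compound 1 and compound 3 cannot be told apart here, so this chloro is not required for growth inhibition at this level in these cells. Nothing available explains why the swap leaves the number within the scatter.

On these data alone, it remains open whether a different group at this position, such as an amine or a methoxy group, would move the number beyond the scatter. The compounds shown also leave open what the remaining chloro contributes, and whether the same swap would read the same way with the side arm of compound 2.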